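This account rests on a few compounds, and the source may have more. Where it says the series, first, only, none or still open, it means among the compounds named here.

Working notes on the diol series.

Compound 1 `O[C@@H](CCc1ccccc1)C[C@@H](O)CCc1ccccc1` gives 128 ug/mL in a functional assay on U-937 cells (Homo sapiens) for antiproliferative activity, read by MTT assay, with a stated time of 48 h; a higher number here means a weaker inhibitor, a lower number a stronger inhibitor. Compound 2 `O[C@H](CCc1ccccc1)C[C@@H](O)CCc1ccccc1` gives 188 ug/mL in this assay, and the step of a 1.5-fold higher number from compound 1 to compound 2 (0.17 log units; within the scatter) is in line with the fact that compounds 1 and 2 differ only in the configuration as drawn, so the two numbers are treated as one level. Going by the values given here, compound 3 `Oc1ccc(CC[C@@H](O)C[C@@H](O)CCc2ccccc2)cc1` gives 33 ug/mL in this assay, and the step of a 5.7-fold lower number from compound 2 to compound 3 (0.76 log units; beyond the scatter) is the only change so far that moved the number beyond the scatter. Compound 3 thus stands at the lowest number of the three, separated from compound 1 and from compound 2 by more than the scatter.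

Compound 4 `COc1cc(CC[C@@H](O)C[C@@H](O)CCc2ccccc2)ccc1O` differs from compound 3 by methoxy in place of hydrogen on an aromatic carbon. Among the compounds with values here, no measured step puts a methoxy on the aromatic ring; the only change at an aromatic carbon is the hydroxy step from compound 2 to compound 3, which is not the same change and gives no direct guide. The free hydroxy of compound 3 is kept in compound 4, so the level of compound 3 is taken as the anchor, and the expected step of a 1.1-fold lower number from compound 3 to compound 4 (0.04 log units; within the scatter) is small, likely within the scatter, with no clear direction. Compound 4 is therefore estimated at 30 ug/mL in this assay, in the range 12 ug/mL to 80 ug/mL.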

Compound 4, half-maximal inhibitory concentration: 32.7 ug/mL
The estimate for compound 4 lay 1.1-fold (0.04 log units) below the measured number, and the stated range covers the measured number.
By their numbers in this assay, from the lowest: compounds 4 and 3 (each within the scatter of the next); then compounds 1 and 2 (each within the scatter of the next).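

In this assay the methoxy on an aromatic carbon, ortho to a hydroxy group, gives a 1.0-fold lower number from compound 3 to compound 4 (0.00 log units; within the scatter), so compound 4 stays at the level of compound 3 with the hydroxy group still in place. Going by these compounds alone, until now the only step beyond the scatter was a 5.7-fold lower number from compound 2 to compound 3 (0.76 log units; beyond the scatter), and the new step shows that this level holds when the ring also carries a methoxy at this position. No measured property available here bears on this step.

The compounds shown leave open whether a methoxy in this place would give the same level on a ring without the hydroxy group, and whether the other configuration of the diol, as in compound 2, would read the same with these ring groups. Also open, as far as these compounds go, is whether a longer chain such as ethoxy, or an amine or a carboxylic acid, in the same place ortho to the hydroxy group would hold the level of compound 3 in this assay or move the number beyond the scatter.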